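From methyl(propyl)amino to piperidin-1-yl on the shared core

The source may report more compounds than this note shows. Statements on the series, on what has been measured and on what is new or still open speak of the compounds shown alone.

Compound 1 `CN(C)c1nc(Cc2c(F)cccc2F)cc(=O)[nH]1`: > 94000 nM
Compound 2 `CCCN(C)c1nc(Cc2c(F)cccc2F)cc(=O)[nH]1`: 85000 nM

For the measured compounds named here, in an ADME assay on MT4 cells (Homo sapiens) for cytotoxicity, read by MTT assay, with a stated time of 4 days (on this read-out higher numbers stand for lower toxicity in this test and lower numbers for higher toxicity in this test), compound 2 gives 85000 nM, the only exact number so far. Compound 1 gives > 94000 nM, which is a limit of the assay and not a number. Compound 2 therefore stands close to the limit of > 94000 nM in this assay, at which 1 of the 2 values shown sits.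

Compound 3 `O=c1cc(Cc2c(F)cccc2F)nc(N2CCCCC2)[nH]1` has not yet been measured in this assay. It differs from compound 2 as follows: piperidin-1-yl in place of methyl(propyl)amino on an aromatic carbon. In short, piperidin-1-yl takes the place of methyl(propyl)amino on an aromatic carbon.

Going by the values given here, the only measured step that bears on this change is an at least 1.1-fold lower number from compound 1 to compound 2 (0.04 log units; that floor lies within the scatter). It therefore gives no sign of a large effect from changing this group. The estimated change is a 1.2-fold lower number from compound 2 to compound 3 (0.08 log units; within the scatter), and no step beyond the scatter is expected. For compound 3, the expected value is 70000 nM, with an estimated range of 30000 nM to 150000 nM.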

Compound 3, half-maximal cytotoxic concentration: > 82000 nM
Compound 3: no number, only a limit (the forecaster's own chance of this, stated with the estimate: 30%); at least 1.1-fold (0.06 log units) between middle value and limit.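

In this assay, compound 3 gives > 82000 nM, which is a limit of the assay and not a number, so the steps to it from compound 1 and compound 2 cannot be read. The compounds shown leave open whether piperidin-1-yl gives a different number from methyl(propyl)amino or dimethylamino on the shared core.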